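A Furan-Bearing Amine Replaces Dimethylamino

A few compounds are considered here, and "the series" means these few. Any claim that something is new, unique, unknown or untested is made for them only; others in the source may bear on it.

Compound 1 (`COc1ccc([C@H]2CC(=O)N(c3cccc(N(C)C)c3)C2)cc1OC1CCCC1`) is the starting point of this account. In a functional assay on HEK293 cells (Homo sapiens) for cytotoxicity (a lower number here means that less compound is tolerated, a higher number that more compound is tolerated), compound 1 gives > 10000 nM as its reading, and this is a limit, not a number. Compound 2 (`COc1ccc([C@H]2CC(=O)N(c3ccccc3C)C2)cc1OC1CCCC1`) gives > 10000 nM in this assay as its reading, and this too is a limit. The measured series therefore amounts to the limit of > 10000 nM in this assay, at which 2 of the 2 values shown sit, and offers no numerical value.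

Compound 3 (`COc1ccc([C@H]2CC(=O)N(c3cccc(NCc4ccoc4)c3)C2)cc1OC1CCCC1`) carries ((furan-3-yl)methyl)amino in place of dimethylamino on an aromatic carbon, meta to a large group (((furan-3-yl)methyl)amino in place of dimethylamino on an aromatic carbon). For the measured compounds named here, the only measured step that bears on this change is 2-methylphenyl in place of 3-(dimethylamino)phenyl on an amide-type nitrogen in a ring, and it is recorded as a step that the two limits leave unreadable from compound 1 to compound 2 with no size to carry over. On that basis, no step beyond the scatter is expected in this assay and no direction can be assigned. This estimate means a step that the limit leaves unreadable from compound 1 to compound 3 as the expected step. For compound 3 the expected value is 12000 nM as a central estimate. The estimated range for compound 3 runs from 5000 nM to 30000 nM and the reading may well arrive only as a limit.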

Compound 3, half-maximal cytotoxic concentration: > 10000 nM
Compound 3 gave a limit, no number; the forecaster's own chance of this, stated with the estimate: 75%; the middle value is on the limit's open side.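

Compound 1 and compound 3 both read only as limits in this assay and the step between them cannot be read. The compounds shown leave open whether ((furan-3-yl)methyl)amino in place of dimethylamino changes the reading at all, and where any numerical value for these compounds would fall, given this one result: the limit of > 10000 nM in this assay, at which 3 of the 3 values shown sit.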